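Extending the Ketone Chain of a Glutamate Receptor Modulator

The compounds below may be only part of what the source reports. "The series", "measured", "known", "first", "only" and "open" are said of these compounds alone.

Among the compounds with values here, compound 2 `CC(=O)c1ccc(OCCCCOc2ccc(C(=O)O)cc2C)c(C)c1O` gives the lowest number of the three compounds measured so far in an assay on HEK293 cells for positive allosteric modulation of metabotropic glutamate receptor 2 (Rattus norvegicus), read by thallium flux, with a stated time of 2.5 min (on this read-out lower numbers stand for an effect already at smaller amounts and higher numbers for an effect only at larger amounts of compound), where compound 2 gives 50 nM. Compound 3 `COc1cc(C(=O)O)ccc1OCCCCOc1ccc(C(C)=O)c(O)c1C` gives 161 nM, and compound 1 `Cc1c(OCCCCOCOc2ccc(C(=O)O)cc2)ccc(C(=O)CC2CCCC2)c1O` gives 228 nM. Within the data shown here, the only step between compounds that differ in one place is a 3.2-fold higher number from compound 2 to compound 3 (0.51 log units; beyond the scatter), a change on an aromatic carbon rather than at the ketone.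

Compound 4 `CCC(=O)c1ccc(OCCCCOc2ccc(C(=O)O)cc2C)c(C)c1O` differs from compound 2 by methyl in place of hydrogen on a saturated chain carbon bound to a carbonyl carbon, so that acetyl becomes propanoyl. Among the measured compounds shown here, no measured step alters this part of the molecule on its own. Compound 1 carries a larger ketone group but also differs from compound 2 elsewhere, so its value shows only that a larger ketone can go together with a higher number than compound 2 in this assay. For the measured compounds named here, with no direct precedent, the step is expected to be small, most likely within the scatter, and if anything toward a somewhat higher number. Compound 4 is therefore estimated at 65 nM, with a range from 25 nM to 170 nM. This estimate corresponds to a 1.3-fold higher number from compound 2 to compound 4 (0.11 log units; within the scatter), which is expected to stay within the usual scatter of this assay.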

Compound 4, half-maximal effective concentration: 82 nM
Compound 4: the middle estimate sits 1.3-fold (0.10 log units) below what was measured, and the stated range covers the measured number.
By their numbers in this assay, from the lowest: compounds 2, 4, 3 and 1 (each within the scatter of the next, the first and the last beyond it).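

In this assay, within the data shown here, the result gives the first direct reading at this position: with acetyl turned into propanoyl and the rest of the molecule unchanged, the record shows a 1.6-fold higher number from compound 2 to compound 4 (0.21 log units; within the scatter), so compound 2 and compound 4 cannot be told apart on this read-out. Among these compounds, the added methyl on the saturated chain carbon bound to the carbonyl carbon is thus accommodated without a change that stands clear of the scatter, whereas the only other step in one place, a 3.2-fold higher number from compound 2 to compound 3 (0.51 log units; beyond the scatter), lies beyond it and concerns an aromatic carbon rather than the ketone. No evidence is available that would explain this result.

On these data alone, what remains open is whether the ketone chain tolerates further growth on the otherwise unchanged molecule of compound 2, for example to butanoyl, to a longer chain or to a cyclopentyl group; compound 1 carries a larger ketone group but also differs from compound 2 elsewhere, so it cannot settle this. Also open is how a hydroxyl group or an amine on this same carbon would read, since the single methyl shown here says nothing about groups of another kind.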